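The compounds below may be only part of what the source reports. "The series", "measured", "known", "first", "only" and "open" are said of these compounds alone.

Compound 1 `COc1cc(-c2nn(-c3cccc(NC(=O)Nc4cccc(C(F)(F)F)c4)c3)cc2-c2ccncc2)ccc1Cl` carries a urea on one side and a pyridine-bearing core on the other. In a functional assay on NCI-H460 cells (Homo sapiens) for inhibition, read by sulforhodamine B assay, with a stated time of 48 h (a lower number here means a stronger inhibitor of growth, a higher number a weaker inhibitor of growth), compound 1 gives 763 nM. Two close relatives have also been measured. Compound 2 `O=C(Nc1cccc(-n2cc(-c3ccncc3)c(-c3ccc(Cl)c(O)c3)n2)c1)Nc1cccc(C(F)(F)F)c1`, in which the methyl on the ring oxygen has been removed, gives 1180 nM. Compound 3 `O=C(Nc1cccc(-n2cc(-c3ccncc3)c(-c3ccc(Cl)c(O)c3)n2)c1)Nc1ccc(Cl)c(C(F)(F)F)c1` adds a chloro to the urea aryl ring of compound 2, and compound 3 gives 1010 nM. The first of these changes brought a 1.5-fold higher number from compound 1 to compound 2 (0.19 log units; within the scatter), the second 1.2-fold lower number from compound 2 to compound 3 (0.07 log units; within the scatter). All three numbers therefore lie within the usual scatter of one another, and compound 1 stands level with compounds 2 and 3 rather than apart from them.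

Compound 4 `COc1cc(-c2nn(-c3cccc(NC(=O)Nc4ccc(Cl)c(Cl)c4)c3)cc2-c2ccncc2)ccc1Cl` differs from compound 1 by a single change: 3,4-dichlorophenyl in place of 3-(trifluoromethyl)phenyl on an amide-type nitrogen. Among the compounds with values here, of the measured steps, only the one from compound 2 to compound 3 touches the same part of the molecule, and it was within the scatter. Within the data shown here, no measured pair swaps trifluoromethyl for chloro, so that part of the change has no direct precedent here. On this basis the expected step of a 1.0-fold higher number from compound 1 to compound 4 (0.02 log units; within the scatter) is none beyond the scatter, and compound 4 is estimated to give 800 nM in this assay, with a range from 350 nM to 1800 nM.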

Compound 4, concentration for 50% growth inhibition: 1110 nM
Compound 4: middle estimate off by 1.4-fold (0.14 log units), on the low side; low and high end bracket the measured number.
By their numbers in this assay, from the lowest: compounds 1, 3, 4 and 2 (each within the scatter of the next).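

In this assay, the exchange of 3-(trifluoromethyl)phenyl for 3,4-dichlorophenyl on the amide-type nitrogen gives a 1.5-fold higher number from compound 1 to compound 4 (0.16 log units; within the scatter), so at this position the two rings cannot be told apart by this read-out. This is the first step shown in which the trifluoromethyl group itself leaves this ring, whereas the earlier step at the same ring, a 1.2-fold lower number from compound 2 to compound 3 (0.07 log units; within the scatter), kept it and added a chloro on a core with a free hydroxyl in place of the methoxy group; both kinds of change, made on these two forms of the core, stay within the scatter. None of the data shown offers a reason why the two rings read alike.

Every compound shown carries trifluoromethyl, chloro or both on this ring, so these results cannot show how far the ring can be altered before the number moves beyond the scatter. From the compounds shown here alone, it remains open whether a plain phenyl ring, or a ring bearing an amine or a carboxylic acid, would still read like compound 1.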